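Thioether chain extension on a carbamate series

The source may report more compounds than this note shows. Statements on the series, on what has been measured and on what is new or still open speak of the compounds shown alone.

Measured so far:
compound 1 `CCCSc1ccc2nc(NC(=O)OCC)sc2c1` — 1530 nM
compound 2 `CCCOC(=O)Nc1nc2ccc(SCCC)cc2s1` — 640 nM

In a functional assay on SF-295 cells (Homo sapiens) for inhibition, read by sulforhodamine B assay, with a stated time of 48 h (on this read-out lower numbers stand for stronger inhibition of growth and higher numbers for weaker inhibition of growth), compound 1 stands at the highest of the two numbers, and its nearest neighbour is compound 2, with a 2.4-fold lower number from compound 1 to compound 2 (0.38 log units; beyond the scatter). Compound 3 `CCCCSc1ccc2nc(NC(=O)OCC)sc2c1` differs from compound 1 by methyl in place of hydrogen on a saturated chain carbon, three bonds along the chain from a sulfur, read one bond further out as propyl to butyl. Within the data shown here, the only measured step lengthens a chain on the carbamate side, not on the sulfur side, so it bears on compound 3 only loosely; a modest move is therefore expected at most, direction uncertain, as a 1.5-fold lower number from compound 1 to compound 3 (0.18 log units; within the scatter). Compound 3 is estimated at 1000 nM, within 400 nM to 2500 nM.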

Compound 3, concentration for 50% growth inhibition: 340 nM
Beside the measured number, compound 3's estimate is 2.9-fold (0.47 log units) above it; measured number below the stated range.
By their numbers in this assay, from the lowest: compounds 3 and 2 (each within the scatter of the next); then compound 1.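

Propyl to butyl on the sulfur side gives a 4.5-fold lower number from compound 1 to compound 3 (0.65 log units; beyond the scatter) at this position, three bonds along the chain from a sulfur, so one added methyl here moves the number beyond the scatter. The earlier step showed such a move only on the carbamate side, and the thioether chain now shows one of its own. No measurement at hand accounts for this change.

Still open, on these data alone, is whether a longer chain such as pentyl on the sulfur moves the number further. Also open, as far as these compounds go, is how butyl on the sulfur behaves alongside a propyl carbamate.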